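Series notes: piperidine replacement at the nitro-bearing ring

The source may hold more compounds than are shown below. What is called first, only, known or untested is meant among the compounds shown, and "the series" means these compounds.

Measured in a functional assay on RKO cells (Homo sapiens) for antiproliferative activity, read by MTT assay, with a stated time of 5 days; on this read-out lower numbers stand for stronger inhibition and higher numbers for weaker inhibition:
- compound 1 `COc1cc[nH]c1/C=C1\C(=O)Nc2ccc([N+](=O)[O-])c(N[C@H]3CC[C@H](O)CC3)c21` gives 8040 nM
- compound 2 `COc1cc[nH]c1/C=C1\C(=O)Nc2ccc([N+](=O)[O-])c(-n3ccnc3)c21` gives 3920 nM
- compound 3 `COc1cc[nH]c1/C=C1\C(=O)Nc2ccc([N+](=O)[O-])c(N3CCC(N)CC3)c21` gives < 10 nM, which is a limit of the assay and not a number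

Among the compounds with values here, compound 3 therefore stands at the low end of what has been measured here, the only value sitting at the limit of < 10 nM in this assay, at which 1 of the 3 values shown sits. Going from compound 1 to compound 2 there is a 2.1-fold lower number from compound 1 to compound 2 (0.31 log units; beyond the scatter), a modest step. The two steps into compound 3 are large: an at least 800-fold lower number from compound 1 to compound 3 (2.90 log units; beyond the scatter) and an at least 390-fold lower number from compound 2 to compound 3 (2.59 log units; beyond the scatter).

Compound 4 `COc1cc[nH]c1/C=C1\C(=O)Nc2ccc([N+](=O)[O-])c(N3CCCC(CO)C3)c21` differs from compound 3 in one place: 3-(hydroxymethyl)piperidin-1-yl in place of 4-aminopiperidin-1-yl on an aromatic carbon. Within the data shown here, no measured step covers this exact exchange. What bears on it is the step from compound 1, whose substituent also carries a hydroxyl and no 4-aminopiperidin-1-yl, to compound 3, which was large. The hydroxymethyl-bearing piperidine in compound 4 sits closer in that respect to compound 1 than to compound 3, so in this assay the estimate is a step of an at least 50-fold higher number from compound 3 to compound 4 (1.69 log units; beyond the scatter), toward weaker inhibition, with wide uncertainty since compound 3 is known only as a limit. Compound 4 is estimated at 500 nM, within 50 nM to 5000 nM.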

Compound 4, half-maximal inhibitory concentration: 124 nM
Beside the measured number, compound 4's estimate is 4.0-fold (0.61 log units) above it, within the range that was stated.
By their numbers in this assay, from the lowest: compound 4; then compound 2; then compound 1. At a limit, below all of these: compound 3.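

In this assay, 3-(hydroxymethyl)piperidin-1-yl on this aromatic carbon, ortho to a nitro group, gives a 32-fold lower number from compound 2 to compound 4 (1.50 log units; beyond the scatter) and a 65-fold lower number from compound 1 to compound 4 (1.81 log units; beyond the scatter), so a large gain at this position does not depend on the amine of 4-aminopiperidin-1-yl, and a hydroxyl-bearing substituent can sit far ahead of (4-hydroxycyclohexyl)amino. The piperidine ring alone still does not carry the full effect, as the exchange for 4-aminopiperidin-1-yl gives an at least 12-fold higher number from compound 3 to compound 4 (1.09 log units; beyond the scatter). That step has only a lower bound, as compound 3 remains at a limit of the assay: the limit of < 10 nM in this assay, at which 1 of the 4 values shown sits.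

The compounds shown do not separate the change of substituent from its shift on the piperidine ring, a question that 3-aminopiperidin-1-yl or 4-(hydroxymethyl)piperidin-1-yl would address directly. On these data alone, how unsubstituted piperidin-1-yl or 4-(dimethylamino)piperidin-1-yl would stand against compound 3 and compound 4 also remains open, as does the true size of the gap between those two compounds.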